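The source may hold more compounds than are shown below. What is called first, only, known or untested is meant among the compounds shown, and "the series" means these compounds.

Three related compounds have been tested in a functional assay on DLD-1 cells (Homo sapiens) for cytotoxicity, with a stated time of 48 h; on this read-out lower numbers stand for stronger inhibition and higher numbers for weaker inhibition. Compound 1 `CC(=O)Oc1ccc2oc(/C=C/[S+](C)[O-])cc(=O)c2c1` gives > 10000 nM as its result. That result is a limit of the assay and not a number, so compound 1 has no exact place on the scale. Compound 2 `COc1ccc2c(=O)cc(/C=C/[S+](C)[O-])oc2c1` gives 7800 nM, and compound 3 `Cc1cccc2oc(/C=C/[S+](C)[O-])cc(=O)c12` gives 5500 nM as its result, which puts these two within the usual scatter of each other.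

Compound 4 `CCCCOc1ccc2oc(/C=C/[S+](C)[O-])cc(=O)c2c1` has not yet been measured. It differs from compound 1 by butyl in place of acetyl on an oxygen on an aromatic ring, which turns acetoxy into butoxy: butyl in place of acetyl on an oxygen on an aromatic ring. Among the compounds with values here, no measured pair shows this change, so any forecast is rough. The best guide is the neighbouring results, compound 2 at 7800 nM and compound 3 at 5500 nM as measured. The expected step of an at least 1.6-fold lower number from compound 1 to compound 4 (0.22 log units; that floor lies within the scatter) is a modest one towards stronger inhibition, and it remains an estimate. For compound 4 the estimated value is 6000 nM, with an expected range from 2000 nM to 15000 nM in this assay.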

Compound 4, half-maximal inhibitory concentration: 4800 nM
Estimate against measurement, compound 4: 1.3-fold (0.10 log units) above; the measured number falls inside the stated range.
By their numbers in this assay, from the lowest: compounds 4, 3 and 2 (each within the scatter of the next). At a limit, above all of these: compound 1.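

In this assay, replacing acetyl with butyl on this oxygen on an aromatic ring, which turns acetoxy into butoxy, gives a step beyond the usual scatter towards stronger inhibition: an at least 2.0-fold lower number from compound 1 to compound 4 (0.31 log units; beyond the scatter). Compound 1 gives > 10000 nM, which is a limit of the assay and not a number. The step is therefore a floor and not a measured size, and the true gap may be wider: the limit of > 10000 nM in this assay, at which 1 of the 4 values shown sits.

A single pair cannot separate the loss of acetyl, with its carbonyl, from the arrival of the butyl chain. It also leaves open how the number would respond to a free hydroxyl on this oxygen, to a longer chain such as octyl, or to an amine at the end of the chain.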